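The source may hold more compounds than are shown below. What is called first, only, known or untested is meant among the compounds shown, and "the series" means these compounds.

Compound 1 `CCC(CC)/N=C(\NC#N)Nc1cccnc1`: 20 mg/kg
Compound 2 `N#CN/C(=N\c1ccccc1)Nc1cccnc1`: 5 mg/kg

In a functional assay on the whole organism (blood, strain Wistar-Okamoto) with Rattus norvegicus as the target, with a stated time of 5 days (on this read-out lower numbers stand for an effect already at smaller amounts and higher numbers for an effect only at larger amounts of compound), compound 2 gives 5 mg/kg, the lowest of the two numbers shown, while compound 1 gives 20 mg/kg. For the measured compounds named here, the only measured step is a 4.0-fold lower number from compound 1 to compound 2 (0.60 log units; beyond the scatter), a change on a double-bonded nitrogen. Compound 3 `N#CN/C(=N\c1ccccc1)Nc1ccncc1` differs from compound 2 at a different place: pyridin-4-yl in place of pyridin-3-yl on an amine nitrogen. Going by the values given here, no measured step touches this amine nitrogen, so nothing in the data speaks for a shift in either direction. The step expected is therefore no change at the digits printed from compound 2 to compound 3 (within the scatter), nothing beyond the scatter. Compound 3 is estimated at 5 mg/kg, within a range from 1.5 mg/kg to 15 mg/kg.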

Compound 3, minimum effective dose: 50 mg/kg
Estimate against measurement, compound 3: 10-fold (1.00 log units) below; the whole stated range lies below it.
By their numbers in this assay, from the lowest: compound 2; then compound 1; then compound 3.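

In this assay, putting pyridin-4-yl in place of pyridin-3-yl on the amine nitrogen gives a 10-fold higher number from compound 2 to compound 3 (1.00 log units; beyond the scatter). This place therefore responds to the change even though the two groups have the same atoms and the same counts of donors and acceptors, so the way those atoms are joined matters here. Nothing measured here explains the shift.

Still open, as far as these compounds go, is how a pyridin-2-yl group on this amine nitrogen would compare. Also open, from the compounds shown here alone, is whether the same step appears with pentan-3-yl on the double-bonded nitrogen.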